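Oxime ether to hydrazone on the shared core

The source may hold more compounds than are shown below. What is called first, only, known or untested is meant among the compounds shown, and "the series" means these compounds.

Three compounds on the shared core have numbers in a physicochemical assay for lipophilicity, using the shake flask method; a lower number here means a more polar compound, a higher number a more lipophilic compound. Compound 1 `Nc1ncnc(Oc2ccc(NC(=O)C3(C(=O)Nc4ccc(F)cc4)CC3)cc2F)c1/C=N/OCCO` gives 2.37. Compound 2 `CC(O)CO/N=C/c1c(N)ncnc1Oc1ccc(NC(=O)C2(C(=O)Nc3ccc(F)cc3)CC2)cc1F` gives 2.75. Compound 3 `Nc1ncnc(Oc2ccc(NC(=O)C3(C(=O)Nc4ccc(F)cc4)CC3)cc2F)c1/C=N/OCC(=O)N1CCOCC1` gives 2.1, the lowest of the three, nearest to compound 1 within the scatter and furthest from compound 2 beyond it. The measured steps are a number 0.38 log units higher from compound 1 to compound 2 (beyond the scatter), a number 0.27 log units lower from compound 1 to compound 3 (within the scatter) and a number 0.65 log units lower from compound 2 to compound 3 (beyond the scatter).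

Compound 4 `N/N=C/c1c(N)ncnc1Oc1ccc(NC(=O)C2(C(=O)Nc3ccc(F)cc3)CC2)cc1F` differs from compound 3 by amino in place of ((morpholin-4-yl)carbonyl)methoxy on a double-bonded nitrogen. Within the data shown here, no measured step exchanges the whole side chain on that nitrogen for a single atom; the nearest guides are a number 0.27 log units lower from compound 1 to compound 3 (within the scatter) and a number 0.65 log units lower from compound 2 to compound 3 (beyond the scatter), both of which alter only the end of the chain and both of which are modest. The leaving group is the largest part of the chain and carries the morpholine ring; the entering amino is small. Among the measured compounds shown here, with no direct precedent, a step within the scatter is expected in this assay, a number 0.20 log units higher from compound 3 to compound 4 (within the scatter). Compound 4 is estimated at 2.3, within a range from 1.8 to 2.8.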

Compound 4, partition coefficient: 2.25
Compound 4: the middle estimate sits 0.05 log units above what was measured; the range from low to high includes it.
By their numbers in this assay, from the lowest: compounds 3, 4 and 1 (each within the scatter of the next); then compound 2.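

In this assay, among these compounds, the earlier steps altered only the end of the chain on the double-bonded nitrogen, whereas amino replaces that whole chain, and the loss of ((morpholin-4-yl)carbonyl)methoxy with its 10 heavy atoms and its ring gives only a number 0.15 log units higher from compound 3 to compound 4 (within the scatter) as the result. Replacing 2-hydroxyethoxy gives a similarly unresolved result, a number 0.12 log units lower from compound 1 to compound 4 (within the scatter), so compounds 1, 3 and 4 cannot be separated here despite the very different groups on that nitrogen. Only the exchange of 2-hydroxypropoxy for amino stands clear, with a number 0.50 log units lower from compound 2 to compound 4 (beyond the scatter), and nothing available accounts for why compound 2 alone stands apart from the other three.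

Open, as far as these compounds go, is how other small groups on that nitrogen would read, such as dimethylamino, methylamino or a plain methoxy, and whether any of them would separate from amino beyond the scatter. Also open, from the compounds shown here alone, is whether a longer chain ending in an amine or a carboxylic acid would stay with compounds 1, 3 and 4 or move away from them as compound 2 does.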